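Methylsulfanyl to Dimethylamino on a Sulfonyl Ketone Scaffold

The compounds below may be only part of what the source reports. "The series", "measured", "known", "first", "only" and "open" are said of these compounds alone.

Measured compounds:
- Compound 1, `CSc1ccc(/C=C(\C(=O)c2ccc(Br)cc2)S(=O)(=O)Cc2ccc(F)cc2)cc1`: 50000 nM
- Compound 2, `CSc1ccc(/C=C(\C(=O)c2ccc(Cl)cc2)S(=O)(=O)Cc2ccc(C)cc2)cc1`: 10000 nM

Two compounds share this core, and both have been tested in a functional assay on DU-145 cells (Homo sapiens) for inhibition, read by trypan blue exclusion, with a stated time of 96 h; on this read-out higher numbers stand for weaker inhibition of growth and lower numbers for stronger inhibition of growth. In this assay compound 1 gives 50000 nM, while compound 2 gives 10000 nM. Compound 2 therefore holds the lower of the two numbers, and its gap to compound 1 is beyond the scatter, so it stands as the stronger inhibitor of growth among the two.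

The next compound, compound 3, `Cc1ccc(CS(=O)(=O)/C(=C/c2ccc(N(C)C)cc2)C(=O)c2ccc(Cl)cc2)cc1`, differs from compound 2 in one place: dimethylamino in place of methylsulfanyl on an aromatic carbon. Going by the values given here, no pair of measured compounds shows this exchange, so its effect has no direct precedent here. With only two data points, and neither bearing on this change, any expectation rests on compound 2 alone.

Compound 3 is expected to stay close to compound 2, with a step of a 2.0-fold lower number from compound 2 to compound 3 (0.30 log units; within the scatter), which may lie within the scatter. The estimated value of compound 3 in this assay is 5000 nM, within a range of 1000 nM to 30000 nM.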

Compound 3, concentration for 50% growth inhibition: 50000 nM
For compound 3 the middle estimate is 10-fold (1.00 log units) below the measured one; measured number above the stated range.
By their numbers in this assay, from the lowest: compound 2; then compounds 1 and 3 (each within the scatter of the next).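

In this assay, going by these compounds alone, the exchange of methylsulfanyl for dimethylamino gives a 5.0-fold higher number from compound 2 to compound 3 (0.70 log units; beyond the scatter) and is the first change in a single place that can be read in this set. It shows that this aromatic carbon, para to a large group, is not indifferent to what it carries: of the two groups seen here, the 4-(methylsulfanyl)phenyl form of compound 2 is the stronger inhibitor of growth, and the 4-(dimethylamino)phenyl form of compound 3 is the weaker, though the step is only modest. Nothing measured here accounts for this difference.

The compounds shown leave open how other groups at this place would compare with methylsulfanyl, such as methoxy, a primary amine, a longer thioether like ethylsulfanyl, or a carboxylic acid, and whether any of them would bring the number below that of compound 2. Within the data shown here, they also leave open whether the same exchange gives a step of like size on the core of compound 1, where no such pair is available.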